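Hydrogen in place of butyl on compound 1

The source may hold more compounds than are shown below. What is called first, only, known or untested is meant among the compounds shown, and "the series" means these compounds.

Compound 1 `CCCCc1c(CCCC)c(OC(C)=O)c2ccccc2c1OC`: 6020 nM
Compound 2 `CCCCCc1c(C(=O)OCC)c(OC)c2ccccc2c1OC(C)=O`: 940 nM

In a functional assay for inhibition, with Rattus norvegicus as the target (a higher number here means a weaker inhibitor, a lower number a stronger inhibitor), compound 1 stands at 6020 nM, the higher of the two numbers and thus the weaker inhibitor, and compound 2 reads 940 nM, a gap beyond the scatter. Compound 3 `CCCCc1cc(OC)c2ccccc2c1OC(C)=O` has not yet been measured. It departs from compound 1 in one place: hydrogen in place of butyl on an aromatic carbon. Going by the values given here, no measured pair shows this change in this assay. The expected result is a small move to a lower number, about the size of the scatter, a 2.0-fold lower number from compound 1 to compound 3 (0.30 log units; within the scatter). For compound 3 the estimated value is 3000 nM, with an expected range from 700 nM to 12000 nM.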

Compound 3, half-maximal inhibitory concentration: 440 nM
Beside the measured number, compound 3's estimate is 6.8-fold (0.83 log units) above it, outside the stated range (below it).
By their numbers in this assay, from the lowest: compound 3; then compound 2; then compound 1.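

Taking the butyl group off this aromatic carbon, ortho to the remaining butyl group and ortho to the methoxy group, gives a 14-fold lower number from compound 1 to compound 3 (1.14 log units; beyond the scatter) in this assay. This position therefore needs no butyl group for a low number, and with hydrogen there the number falls well beyond the scatter. Nothing measured here explains the size of this step.

As far as these compounds go, what stays open is how a smaller group at this carbon would read, such as a methyl or ethyl chain, and whether an amine or a carboxylic acid there would keep the lower number.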